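This account rests on a few compounds, and the source may have more. Where it says the series, first, only, none or still open, it means among the compounds named here.

Measured compounds in the series:

compound 1 `COCCOc1cc2oc(=O)n(CCC(=O)O)c2cc1Cl`, an assay for inhibition of kynurenine 3-monooxygenase (Homo sapiens), read by mass spectrometry, with a stated time of 1 h (on this read-out higher numbers stand for weaker inhibition and lower numbers for stronger inhibition), 31.6 nM
compound 2 `Cc1ccc([C@@H](C)Oc2cc3onc(CCC(=O)O)c3cc2Cl)nc1`, this assay 3.16 nM
compound 3 `COc1cc2oc(=O)n(CCC(=O)O)c2cc1Cl`, this assay 12.6 nM

Compound 2 gives the lowest number of the three; compound 3 stands above it and compound 1 higher still, both gaps beyond the scatter. Among the measured pairs only one single-site step is available: from compound 1 to compound 3, a 2.5-fold lower number from compound 1 to compound 3 (0.40 log units; beyond the scatter), hydrogen in place of methoxymethyl on the chain carbon bound to the ring oxygen.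

Compound 4 `C[C@@H](Oc1cc2onc(CCC(=O)O)c2cc1Cl)c1ccc(Cl)cn1` is not yet measured. Its change from compound 2 is chloro in place of methyl on an aromatic carbon. For the measured compounds named here, no measured step touches this position: the step from compound 1 to compound 3 concerns the chain on the ring oxygen and not the pyridine substituent, so it does not bear on this change. With nothing in the data pointing either way, the expected step from compound 2 to compound 4 is a 1.0-fold higher number from compound 2 to compound 4 (0.01 log units; within the scatter), within the scatter. For compound 4 the estimate in this assay is 3.2 nM, with a range from 1.2 nM to 8.5 nM.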

Compound 4, half-maximal inhibitory concentration: 3.16 nM
The estimate for compound 4 lay 1.0-fold (0.01 log units) above the measured number; measured number inside the range.
By their numbers in this assay, from the lowest: compounds 2 and 4 (each within the scatter of the next); then compound 3; then compound 1.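

In this assay, 5-methylpyridin-2-yl gives way to 5-chloropyridin-2-yl with no change at the digits printed from compound 2 to compound 4 (within the scatter). For the compounds shown here, this is the first measured step on the pyridine ring, and it places chloro and methyl on a level at this aromatic carbon, two atoms from the ring nitrogen; earlier steps touched only the chain on the ring oxygen. The finding holds for this one pair and gives no trend across substituents, and nothing at hand bears on why the two groups read alike.

From the compounds shown here alone, whether a nitrile, a methoxy group, an amine or a longer chain on this same carbon would keep the number at this level remains open. Also open, going by these compounds, is whether an amide in place of the carboxylic acid would leave the number unchanged in compounds carrying either pyridine substituent.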